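Swapping the 2-Phenylethenyl Arm for Furan-2-yl

This account rests on a few compounds, and the source may have more. Where it says the series, first, only, none or still open, it means among the compounds named here.

Compound 1 `Cc1ccccc1-n1nc(C)c2c1NC(=O)[C@H](C)S[C@@H]2c1ccc(/C=C/c2ccccc2)cc1` has no single number in an assay on isolated protein for agonist activity at Bile acid receptor (Homo sapiens), read by AlphaScreen, with a stated time of 30 min; on this read-out higher numbers stand for an effect only at larger amounts of compound and lower numbers for an effect already at smaller amounts: compound 1 is reported simply as "not active" (no number reported). The only figure in this set belongs to compound 2 `Cc1ccc(-n2nc(C)c3c2NC(=O)[C@H](C)S[C@@H]3c2ccc(Oc3ccccc3)cc2)cc1`, which in this assay gives 3400 nM. Compound 3 `Cc1ccccc1-n1nc(C)c2c1NC(=O)[C@H](C)S[C@@H]2c1ccc(-c2ccco2)cc1` differs from compound 1 by furan-2-yl in place of 2-phenylethenyl on an aromatic carbon. Going by the values given here, no measured step covers this pair, so the size of the move in this assay is open; since compound 1 shows no activity, any reported number for compound 3 would point toward an effect at smaller amounts, but how large a change this is cannot be read from the data. Compound 3 is expected near 5000 nM, in the range 1200 nM to 30000 nM.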

Compound 3, half-maximal effective concentration: 3600 nM
Beside the measured number, compound 3's estimate is 1.4-fold (0.14 log units) above it; the range from low to high includes it.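

Going by these compounds alone, compound 1 carries no number, so no step to compound 3 can be read. The compounds shown leave open how far furan-2-yl in place of 2-phenylethenyl moves the effect, and no measured evidence bears on this result.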